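Indole sulfonamide partial agonists: piperidine to pyrrolidine swap

The compounds below may be only part of what the source reports. "The series", "measured", "known", "first", "only" and "open" are said of these compounds alone.

Measured compounds:
- compound 3 `CCN1CCCC(n2cc(S(=O)(=O)c3ccccc3)c3ccccc32)C1` — 52%
- compound 1 `O=S(=O)(c1cccc(F)c1)c1cn(C2CCNC2)c2ccc(Cl)cc12` — "not determined" (no result reported)
- compound 2 `O=S(=O)(c1cccc(F)c1)c1cn(C2CCNC2)c2cc(F)ccc12` — "not determined" (no result reported)

In a functional assay on HeLa cells for agonist activity at 5-hydroxytryptamine receptor 6 (Homo sapiens), read by cAMP accumulation and immunoassay, with a stated time of 10 min (on this read-out lower numbers stand for smaller maximal responses and higher numbers for larger maximal responses), compound 1 gives "not determined" (no result reported). In this assay compound 2 gives "not determined" (no result reported). No number was reported for either of them, so the only figure in this series belongs to compound 3. In this assay compound 3 gives 52%, a response that reaches about half of the control, which places it as the sole reference point; nothing can be said of where it stands relative to the others.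

Compound 4 `O=S(=O)(c1ccccc1)c1cn(C2CCNC2)c2ccccc12` is still to be measured in this assay. Its difference from compound 3 is pyrrolidin-3-yl in place of 1-ethylpiperidin-3-yl on an aromatic nitrogen. Among the measured compounds shown here, no step between two measured compounds is available, so there is no precedent for how this kind of change moves the maximal response.

Given that, the expected step for compound 4 is small: a number 3 percentage points higher from compound 3 to compound 4 (within the scatter) is estimated to fall within the usual scatter, with the direction open. Compound 4 is expected to give 55% in this assay, with a range from 25% to 85%, the width reflecting that only compound 3 anchors the estimate.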

Compound 4, largest response reached (Emax), in percent of the reference or control that the assay uses: 70%
Compound 4: the middle estimate sits 15 percentage points below what was measured, within the range that was stated.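

In this assay, among the compounds shown here, a number 18 percentage points higher from compound 3 to compound 4 (beyond the scatter) is the first step that can be read, and it shows that the group on the aromatic nitrogen does move the maximal response. It also shows that 1-ethylpiperidin-3-yl is not required for a response at this position, since the smaller pyrrolidin-3-yl, which has a hydrogen-bond donor that the group it replaces lacks, gives a response higher than the scatter alone would account for. For the compounds shown here, the single step changes ring size, removes the ethyl group and adds that donor all at once, and nothing measured here separates these changes or accounts for the rise.

Still open, on these data alone, is which of these changes carries the step, a question that piperidin-3-yl and 1-ethylpyrrolidin-3-yl, each differing from one of the two compounds in a single feature, could address. Steps involving compound 1 and compound 2 cannot be read, as neither has a number, so the effect of the fluorine and chlorine substituents on the shared core on this response also remains unknown.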